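Methoxycarbonyl for acetyl on the pendant amide nitrogen

The source may hold more compounds than are shown below. What is called first, only, known or untested is meant among the compounds shown, and "the series" means these compounds.

Compound 1 `CCCCCCCN1C(=O)[C@H](Cc2ccc(-c3cc(OC)c(OC)c(OC)c3)cc2)N(C)C(=O)[C@@H]1C` gives 54% in a functional assay on cells for agonist activity at follicle-stimulating hormone receptor (Homo sapiens), read by cAMP accumulation; a higher number here means a larger maximal response, a lower number a smaller maximal response.
Compound 2 `CCCCCCCCN1C(=O)[C@H](Cc2ccc(-c3cc(OC)c(OC)c(OC)c3)cc2)N(C)C(=O)[C@@H]1C` gives 47% in this assay.
Compound 3 `CCCCCCCCN1C(=O)[C@H](Cc2ccc(-c3cccc(CN(CCCC)C(C)=O)c3)cc2)N(C)C(=O)[C@@H]1C` gives 57% in this assay.

The single one-place step among these three compounds, a number 7 percentage points lower from compound 1 to compound 2 (within the scatter), changes only the chain on the ring nitrogen and leaves the maximal response essentially where it was. Compound 3 carries a different substituent on the pendant ring and shows the numerically top value of the three, but its gaps to compound 1 and to compound 2 both fall within the usual scatter, so the three numbers are best read as one common level.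

Compound 4 `CCCCCCCCN1C(=O)[C@H](Cc2ccc(-c3cccc(CN(CCCC)C(=O)OC)c3)cc2)N(C)C(=O)[C@@H]1C` differs from compound 3 by methoxy in place of methyl on a carbonyl carbon. Among the compounds with values here, no measured step touches this part of the molecule: the only step available concerns the chain on the ring nitrogen, and even that stayed within the scatter. Within the data shown here, nothing among the measured compounds therefore points to a shift beyond the scatter in this assay, and compound 4 is expected to remain near compound 3, with a number 2 percentage points lower from compound 3 to compound 4 (within the scatter) as the estimated step. Compound 4 is estimated at 55%, within a range from 40% to 70%.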

Compound 4, largest response reached (reported as efficacy), in percent of the reference or control that the assay uses: 49%
Beside the measured number, compound 4's estimate is 6 percentage points above it, within the range that was stated.
By their numbers in this assay, from the lowest: compounds 2, 4, 1 and 3 (each within the scatter of the next).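

Methoxycarbonyl in place of acetyl on the pendant amide nitrogen gives the first reading at this position: in this assay the step is a number 8 percentage points lower from compound 3 to compound 4 (within the scatter). Methoxy in place of methyl on this carbonyl carbon, a swap that brings in one oxygen and one hydrogen-bond acceptor, therefore yields a maximal response that cannot be told apart from that of the acetyl compound, and the earlier compounds, whose only one-place step concerned the chain on the ring nitrogen, could not show this. No measurement available here offers an explanation for this outcome.

What the compounds shown leave open is whether a different group on this carbonyl carbon, such as ethoxy, a dimethylamino group or a phenyl ring, would move the maximal response beyond the scatter. Also open, going by these compounds, are the part played by the butyl chain on the same nitrogen, whether a longer chain or a carboxylic acid there would read differently, and whether methoxycarbonyl behaves alike with the shorter chain that compound 1 carries on the ring nitrogen.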